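Replacing the Benzodioxin Ring With a Nitrophenyl Group

A few compounds are considered here, and "the series" means these few. Any claim that something is new, unique, unknown or untested is made for them only; others in the source may bear on it.

Measured so far, all in an ADME assay on Raji cells (Homo sapiens) for cytotoxicity, read by CellTiter-Glo and resazurin assay, with a stated time of 72 h; a higher number here means that more compound is needed for the effect, a lower number that less compound is needed:
Compound 1 `CC(C)N(Cc1cccc(OCCCCCC(=O)O)c1)C(=O)c1ccc(-c2cccc([N+](=O)[O-])c2)cc1` gives > 26000 nM; this is a limit of the assay, not a number.
Compound 2 `CCOC(=O)CCCCCOc1cccc(CN(C(=O)c2ccc(-c3cccc(Oc4ccccc4)c3)cc2)C(C)C)c1` gives > 19600 nM; this too is a limit.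
Compound 3 `CCOC(=O)CCCCCOc1cccc(CN(C(=O)c2ccc(-c3ccc4c(c3)OCCO4)cc2)C(C)C)c1` gives > 24400 nM; again a limit.

Within the data shown here, compound 3 thus stands at the limit of > 24400 nM in this assay, at which 1 of the 3 values shown sits, and the two other values are limits as well, so no compound here has a definite number. Compound 4 `CCOC(=O)CCCCCOc1cccc(CN(C(=O)c2ccc(-c3cccc([N+](=O)[O-])c3)cc2)C(C)C)c1` differs from compound 3 in one place: 3-nitrophenyl in place of 2,3-dihydro-1,4-benzodioxin-6-yl on an aromatic carbon. Among the measured compounds shown here, no step between measured compounds is available to size this change. With every measured compound sitting at a limit, the expectation is no movement beyond the scatter, and a value again at or past the limit. Compound 4 is therefore estimated at 30000 nM, within 15000 nM to 80000 nM. The expected step is a step that the limit leaves unreadable from compound 3 to compound 4.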

Compound 4, half-maximal effective concentration: > 26000 nM
Compound 4 was reported as a limit; the forecaster's own chance of this, stated with the estimate: 85%; the middle value lies beyond the limit too.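

Among these compounds, compound 1, compound 2, compound 3 and compound 4 all sit at limits of the assay, and no step between them can be read. From the compounds shown here alone, whether any of these structures would give a definite number in this assay stays open.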